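The compounds below may be only part of what the source reports. "The series", "measured", "known", "first", "only" and "open" are said of these compounds alone.

Working notes on the series. For the measured compounds named here, in a functional assay on KB cells (Homo sapiens) for antiproliferative activity, read by sulforhodamine B assay, with a stated time of 48 h (a higher number here means a weaker inhibitor of growth, a lower number a stronger inhibitor of growth), compound 1 (`COc1ccc(S(=O)(=O)Nc2ccccc2CCc2ccc(C(=O)Nc3ccccc3N)cc2)cc1`) gives 23 nM, the lower of the two numbers measured so far and so the stronger growth inhibition. Compound 2 (`COc1ccc(S(=O)(=O)Nc2ccccc2CCc2ccc(C(=O)Nc3ccccc3N)cc2)cc1OC`) gives 888 nM.

Compound 3 (`COc1ccc(S(=O)(=O)Nc2ccccc2CCc2ccc(C(=O)Nc3ccc(N)cc3)cc2)cc1`) has the same atoms as compound 1, joined differently: 4-aminophenyl in place of 2-aminophenyl on an amide-type nitrogen. The core of compound 1 stays untouched, and only the amino group on the anilide ring changes place.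

Going by the values given here, one measured step bears on this, and only indirectly. The a 39-fold higher number from compound 1 to compound 2 (1.59 log units; beyond the scatter) is large and comes from methoxy in place of hydrogen on an aromatic carbon, so it lies at another place in the molecule. Among the compounds with values here, it shows that a single change can cost compound 2 much of the activity of compound 1, but no measured compound tests the 2-aminophenyl group itself.

A large step towards a higher number is therefore expected in this assay, with wide uncertainty. The expected step is an 87-fold higher number from compound 1 to compound 3 (1.94 log units; beyond the scatter). For compound 3 the estimated value is 2000 nM, with an expected range of 300 nM to 12000 nM.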

Compound 3, concentration for 50% growth inhibition: 286 nM
Estimate against measurement, compound 3: 7.0-fold (0.84 log units) above, outside the stated range (below it).
By their numbers in this assay, from the lowest: compound 1; then compound 3; then compound 2.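

The position of the amino group on the anilide ring is now tested directly in this assay: a 12-fold higher number from compound 1 to compound 3 (1.09 log units; beyond the scatter) arises from 4-aminophenyl in place of 2-aminophenyl on an amide-type nitrogen, with the shared core untouched and the counted atoms, donors and acceptors of the group unchanged. The placement of the amino group alone therefore matters at this position, and a step beyond the scatter can arise here as well as at the methoxy-bearing ring, yet compound 3 still inhibits growth at 286 nM. Nothing available gives a reason for this step.

Still open, as far as these compounds go, is whether the amino group itself matters or only its placement, a question that a plain phenyl or a 2-hydroxyphenyl on the same amide-type nitrogen would address. Also open, from the compounds shown here alone, is whether 4-aminophenyl in place of 2-aminophenyl would give a step of similar size on the core of compound 2, which carries the added methoxy group.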